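The source may hold more compounds than are shown below. What is called first, only, known or untested is meant among the compounds shown, and "the series" means these compounds.

Compound 1 `COC(=O)c1ccc(NCc2cncn2Cc2ccccc2C(C)(C)C)cc1-c1ccccc1`: in a toxicity assay on NIH3T3 cells (Mus musculus) for cytotoxicity, read by resazurin assay (a lower number here means that less compound is needed, a higher number that more compound is needed for the effect), compound 1 gives "not determined" (no result reported). Compound 2 `Cc1cccc(-c2cccc(NCc3cncn3Cc3ccccc3)c2)c1`: in this assay compound 2 gives > 1000 nM, a limit of the assay. Compound 3 `c1ccc(Cn2cncc2CNc2cccc(-c3cccnc3)c2)cc1`: in this assay compound 3 gives > 1000 nM, likewise a limit.

Compound 1 thus stands nowhere on the numbers: it has no result in this assay, and the two other values sit at the limit of > 1000 nM in this assay, at which 2 of the 3 values shown sit. Compound 4 `COC(=O)c1ccc(NCc2cncn2Cc2ccccc2C)cc1-c1ccccc1` differs from compound 1 by methyl in place of tert-butyl on an aromatic carbon. Among the compounds with values here, the one measured step, a step that the two limits leave unreadable from compound 2 to compound 3, runs between two limits and carries no size, so no step bears on the change from tert-butyl to methyl. The expectation rests on the limits alone. Compound 4 is expected to give 3000 nM, between 1000 nM and 30000 nM, most probably reported again as a limit.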

Compound 4, half-maximal effective concentration: 10000 nM
Compound 4: the middle estimate sits 3.3-fold (0.52 log units) below what was measured; measured number inside the range.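

In this assay compound 1 gives "not determined" (no result reported) and compound 4 gives 10000 nM, so no step can be read between compound 1 and compound 4. The compounds shown leave open what replacing tert-butyl with methyl does in this assay.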